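Lengthening the Chain Between Sulfur and the Phenyl Ring

This account rests on a few compounds, and the source may have more. Where it says the series, first, only, none or still open, it means among the compounds named here.

Compound 1 `[O-][S+](/C=C/c1ccc(O)c(O)c1)Cc1ccccc1` and compound 2 `[O-][S+](/C=C/c1ccc(O)c(O)c1)CCc1ccccc1` share a common core and differ only in the chain that links the sulfur to a phenyl ring. In a functional assay on BV-2 cells (Mus musculus) for inhibition, read by Griess assay, with stated times of 3 h and 24 h (a lower number here means a stronger inhibitor, a higher number a weaker inhibitor), compound 1 gives 50300 nM and compound 2 gives 42600 nM; these two numbers lie within the scatter of each other, so neither compound stands apart. Compound 3 `[O-][S+](/C=C/c1ccc(O)c(O)c1)CCCc1ccccc1` continues the series: benzyl in place of phenyl on a saturated chain carbon, two bonds along the chain from a sulfur. The expected step of a 1.1-fold lower number from compound 2 to compound 3 (0.05 log units; within the scatter) is small, resting on compound 1 at 50300 nM and compound 2 at 42600 nM lying within the scatter of each other. For compound 3 the estimate is 38000 nM, with a range from 15000 nM to 95000 nM.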

Compound 3, half-maximal inhibitory concentration: 28600 nM
The estimate for compound 3 lay 1.3-fold (0.12 log units) above the measured number; the measured number falls inside the stated range.
By their numbers in this assay, from the lowest: compounds 3, 2 and 1 (each within the scatter of the next).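

Benzyl in place of phenyl on a saturated chain carbon, two bonds along the chain from a sulfur, gives a 1.5-fold lower number from compound 2 to compound 3 (0.17 log units; within the scatter) in this assay. This second lengthening of the chain therefore does not set compound 3 apart from compound 2, so this position has so far tolerated the change without a clear shift in the number. Nothing available bears on what lies behind this result. On these data alone, whether a longer chain, or an amine or a carboxylic acid at this position, would move the number beyond the scatter remains open.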